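The source may hold more compounds than are shown below. What is called first, only, known or untested is meant among the compounds shown, and "the series" means these compounds.

Of the compounds shown here, two have been measured in a functional assay for antagonist activity at P2X purinoceptor 7 (Homo sapiens), read by FLIPR and calcium flux; a lower number here means a stronger inhibitor, a higher number a weaker inhibitor. Compound 1, `Cc1ccccc1CNc1ncnn1-c1cccc(Cl)c1Cl`, gives 20.9 nM in this assay. Compound 2, `Clc1cccc(-n2cnnc2NCc2cccnc2)c1Cl`, gives 355 nM in this assay. Of these two numbers, compound 2 stands at the higher one, and the gap between compound 2 and compound 1 is wider than the usual scatter of repeated measurements, so compound 2 is the weaker inhibitor of the two.

Compound 3, `CC(C)N1CCCN(c2ncccc2CNc2nncn2-c2cccc(Cl)c2Cl)CC1`, is an untested variation of compound 2. The change is 4-isopropyl-1,4-diazepan-1-yl in place of hydrogen on an aromatic carbon. Going by the values given here, no measured pair shows what such a change does here, so the size and direction of its effect can only be estimated. Because compound 2 gives 355 nM while compound 1 gives 20.9 nM, there is room for a lower number, and the expectation is a modest step downward, a 5.9-fold lower number from compound 2 to compound 3 (0.77 log units; beyond the scatter), in this assay. The estimate for compound 3 in this assay is 60 nM, with a plausible range from 10 nM to 400 nM.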

Compound 3, half-maximal inhibitory concentration: 67.6 nM
Estimate against measurement, compound 3: 1.1-fold (0.05 log units) below; measured number inside the range.
By their numbers in this assay, from the lowest: compound 1; then compound 3; then compound 2.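

The carbon next to the ring nitrogen, on the six-membered aromatic ring with 1 nitrogen, can carry far more than hydrogen without loss of inhibition: in this assay, putting 4-isopropyl-1,4-diazepan-1-yl there gives a 5.3-fold lower number from compound 2 to compound 3 (0.72 log units; beyond the scatter). Compound 2 alone could not show this, since it offers only the unsubstituted ring and says nothing about whether this carbon accepts a substituent, let alone one of 10 heavy atoms with a seven-membered non-aromatic ring. The step therefore marks this position as one where a large group is compatible with a stronger inhibitor, although no measurement here explains why the number falls.

The compounds shown leave open which part of the new group matters, since the seven-membered ring and its isopropyl group enter together, and a single step cannot separate them. Whether a smaller amine such as dimethylamine, a morpholine ring, or the same 1,4-diazepan-1-yl ring carrying a methyl group or only hydrogen in place of the isopropyl would give a similar number remains an open question.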